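Compound 4: a Fluorine Moved on the Carbonyl Ring

The source may report more compounds than this note shows. Statements on the series, on what has been measured and on what is new or still open speak of the compounds shown alone.

Compound 1 `[O-][S+](CCNC1CCN(Cc2ccc(F)cc2)CC1)C(c1ccc(F)cc1)c1ccc(F)cc1`: 26.5 nM
Compound 2 `O=C(c1ccc(F)cc1)N1CCC(NCC[S+]([O-])C(c2ccc(F)cc2)c2ccc(F)cc2)CC1`: 1440 nM
Compound 3 `Fc1ccc(C(SCCNC2CCN(CC3CC3)CC2)c2ccc(F)cc2)cc1`: 269 nM

In an assay on membranes from Cortex for displacement of a labelled ligand from Sigma non-opioid intracellular receptor 1 (Cavia porcellus), read by scintillation counting, with a stated time of 120 min (on this read-out higher numbers stand for weaker inhibition and lower numbers for stronger inhibition), compound 2 gives the highest number of the three; compound 3 stands nearest to it and compound 1 furthest, both gaps beyond the scatter. Compound 4 `O=C(c1ccccc1F)N1CCC(NCC[S+]([O-])C(c2ccc(F)cc2)c2ccc(F)cc2)CC1` differs from compound 2 by 2-fluorophenyl in place of 4-fluorophenyl on a carbonyl carbon. For the measured compounds named here, the only measured step, a 54-fold higher number from compound 1 to compound 2 (1.74 log units; beyond the scatter), concerns the group on the ring nitrogen and not where the fluorine sits, so it does not bear on this change directly. Going by the values given here, no measured pair shows what moving a fluorine around that ring does, and nothing points to a step beyond the scatter. Compound 4 is therefore expected to give about 1300 nM (range 450 nM to 4000 nM), a step of a 1.1-fold lower number from compound 2 to compound 4 (0.04 log units; within the scatter) in this assay.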

Compound 4, inhibition constant: 1310 nM
Compound 4: the middle estimate sits 1.0-fold (0.00 log units) below what was measured; the range from low to high includes it.
By their numbers in this assay, from the lowest: compound 1; then compound 3; then compounds 4 and 2 (each within the scatter of the next).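

In this assay, the step of a 1.1-fold lower number from compound 2 to compound 4 (0.04 log units; within the scatter) shows that, on a carbonyl carbon whose other neighbour is the amide-type nitrogen in a ring, 2-fluorophenyl and 4-fluorophenyl cannot be told apart. The step of a 49-fold higher number from compound 1 to compound 4 (1.69 log units; beyond the scatter) shows that the large gap to the 4-fluorobenzyl compound remains with the fluorine in either place. Nothing available explains why the fluorine's place leaves the reading within the scatter. The compounds shown leave open whether a plain phenyl, or a chlorine in place of the fluorine, would read the same on this carbonyl carbon.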